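The source may hold more compounds than are shown below. What is called first, only, known or untested is meant among the compounds shown, and "the series" means these compounds.

Compound 1 `COc1ccc(/C=C2\CCC/C(=C\c3cccc(OC)c3OC)C2=O)cc1OC` gives 14400 nM
Compound 2 `COc1cccc(/C=C2\CCC/C(=C\c3ccc(O)c(Cl)c3)C2=O)c1OC` gives > 20000 nM (a limit, not a number)

Both values come from a functional assay on A549 cells (Homo sapiens) for cytotoxicity, read by MTT assay, with a stated time of 72 h (on this read-out lower numbers stand for stronger inhibition and higher numbers for weaker inhibition), and only compound 1 gives a true number, 14400 nM in this test. Compound 2 stands at the limit of > 20000 nM in this assay, at which 1 of the 2 values shown sits, and so has a limit instead of a measured potency.

Compound 3 `COc1cc(/C=C2\CCC/C(=C\c3cccc(OC)c3OC)C2=O)ccc1O` is reached from compound 2 by one change, methoxy in place of chloro on an aromatic carbon, ortho to a hydroxy group. This turns 3-chloro-4-hydroxyphenyl into 4-hydroxy-3-methoxyphenyl (methoxy in place of chloro on an aromatic carbon), while the rest of the molecule stays the same.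

Within the data shown here, no pair of measured compounds differs in one place, so the size of this change in this assay cannot be read from the data. Among the measured compounds shown here, the only number to lean on is that compound 1 gives 14400 nM and compound 3 is therefore expected to land in that same weak region. The expected move is an at least 1.5-fold lower number from compound 2 to compound 3 (0.18 log units; that floor lies within the scatter) and it is estimated to be small, toward stronger inhibition if it shows at all. For compound 3 the estimated value is 13000 nM with an expected range from 5000 nM to 26000 nM in this test.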

Compound 3, half-maximal inhibitory concentration: > 20000 nM
Compound 3: no number, only a limit (the forecaster's own chance of this, stated with the estimate: 35%); middle value at least 1.5-fold (0.18 log units) from the limit.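

In this assay compound 3 gives > 20000 nM as its result, and this is a limit, not a number. Among these compounds, the one step that can be read is hydrogen in place of methyl on an oxygen on an aromatic ring, which gives an at least 1.3-fold higher number from compound 1 to compound 3 (0.14 log units; that floor lies within the scatter) and so shows that the hydroxy group of compound 3 does not bring stronger inhibition than the methoxy group that stands in its place in compound 1. Methoxy in place of chloro, ortho to the hydroxy group, is the change this result was meant to size, yet compound 2 and compound 3 leave it unreadable, and no size can be given for it because both compounds stand at the same limit: the limit of > 20000 nM in this assay, at which 2 of the 3 values shown sit.

From the compounds shown here alone, how far apart compound 2 and compound 3 really lie therefore stays open, since a limit hides any difference that may exist beyond it. Also open, going by these compounds, is whether another group at this place on the ring, such as an amine, a carboxylic acid or the longer ethoxy chain, would bring the result down to a true number in this test.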